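The compounds below may be only part of what the source reports. "The series", "measured", "known", "first", "only" and "open" are said of these compounds alone.

Measured so far in a functional assay on SNB-19 cells (Homo sapiens) for antiproliferative activity, with a stated time of 48 h; a lower number here means a stronger inhibitor of growth, a higher number a weaker inhibitor of growth:
Compound 1 `Cc1cc(O)c(C2=NN(c3ccc(S(N)(=O)=O)cc3)C(c3ccccc3O)C2)cc1Cl` gives 15200 nM.
Compound 2 `Cc1cc(O)c(C2=NN(c3ccc(S(N)(=O)=O)cc3)C(c3ccccc3Cl)C2)cc1Cl` gives 16300 nM.
Compound 3 `Cc1cc(O)c(C2=NN(c3ccc(S(N)(=O)=O)cc3)C(/C=C/c3ccccc3)C2)cc1Cl` gives 19900 nM.

Going by the values given here, of the three numbers, the one for compound 3 is the highest, yet the steps of a 1.3-fold higher number from compound 1 to compound 3 (0.12 log units; within the scatter) and a 1.2-fold higher number from compound 2 to compound 3 (0.09 log units; within the scatter) both lie within the scatter, so the three compounds cannot be told apart in this assay. The step of a 1.1-fold higher number from compound 1 to compound 2 (0.03 log units; within the scatter) is likewise within the scatter.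

Compound 4 `COc1ccc(C2CC(c3cc(Cl)c(C)cc3O)=NN2c2ccc(S(N)(=O)=O)cc2)cc1OC` has not yet been measured. It differs from compound 3 by 3,4-dimethoxyphenyl in place of 2-phenylethenyl on a saturated ring carbon. Among the compounds with values here, the steps that bear on this change are those in which the group on the same saturated ring carbon was exchanged: a 1.3-fold higher number from compound 1 to compound 3 (0.12 log units; within the scatter) and a 1.2-fold higher number from compound 2 to compound 3 (0.09 log units; within the scatter), each within the scatter. Three different groups at this position have therefore given numbers that are indistinguishable, and a fourth group is expected to do the same, with no step beyond the scatter in either direction in this assay.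

Compound 4 is accordingly estimated at 17000 nM, with a range from 8000 nM to 36000 nM. The step this estimate implies, a 1.2-fold lower number from compound 3 to compound 4 (0.07 log units; within the scatter), is expected to stay within the scatter.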

Compound 4, concentration for total growth inhibition: 89300 nM
Beside the measured number, compound 4's estimate is 5.3-fold (0.72 log units) below it, outside the stated range (above it).
By their numbers in this assay, from the lowest: compounds 1, 2 and 3 (each within the scatter of the next); then compound 4.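

In this assay, the group on this saturated ring carbon turns out to matter: the numbers show a 4.5-fold higher number from compound 3 to compound 4 (0.65 log units; beyond the scatter), a 5.5-fold higher number from compound 2 to compound 4 (0.74 log units; beyond the scatter) and a 5.9-fold higher number from compound 1 to compound 4 (0.77 log units; beyond the scatter), each beyond the scatter. The position therefore accepts 2-phenylethenyl, 2-chlorophenyl and 2-hydroxyphenyl without a difference that can be read, whereas 3,4-dimethoxyphenyl gives a modestly weaker inhibitor of growth than any of them. No measurement shown here explains why this group behaves differently.

A plain phenyl or a 4-methoxyphenyl group on this carbon would help show whether the weaker growth inhibition needs both methoxy groups or just one. From the compounds shown here alone, it also remains open whether a different group, such as a 4-aminophenyl or a 4-carboxyphenyl, could give a number clearly lower than those of compound 1, compound 2 and compound 3.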